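The source may report more compounds than this note shows. Statements on the series, on what has been measured and on what is new or still open speak of the compounds shown alone.

Measured compounds and values:
Compound 1 `C=C1CCC[C@H]2[C@](C)(CC3=C(O)C(=O)C=C(OC)C3=O)[C@@H](C)CC[C@]12C` gives 3900 nM in a functional assay on MCF7 cells (Homo sapiens) for cytotoxicity, read by sulforhodamine B assay, with a stated time of 48 h; on this read-out higher numbers stand for weaker inhibition of growth and lower numbers for stronger inhibition of growth.
Compound 2 `C=C1CCC[C@H]2[C@](C)(Cc3c(O)c(O)cc4ncoc34)[C@@H](C)CC[C@]12C` gives 35000 nM in this assay.
Compound 3 `C=C1CCC[C@H]2[C@](C)(CC3=C(O)C(=O)C=C(NCC(=O)O)C3=O)[C@@H](C)CC[C@]12C` gives 10000 nM in this assay.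

Compound 3 holds the second highest of the three numbers in this assay; compound 1 sits nearest, compound 2 furthest. Compound 4 `C=C1CCC[C@H]2[C@](C)(CC3=C(O)C(=O)C=C(NCCC(=O)O)C3=O)[C@@H](C)CC[C@]12C` differs from compound 3 by carboxymethyl in place of carboxy on a saturated chain carbon bound to an amine nitrogen. For the measured compounds named here, the only measured step touching this part of the core is a 2.6-fold higher number from compound 1 to compound 3 (0.41 log units; beyond the scatter), a modest one. Going by the values given here, no measured step lengthens the chain on the amine nitrogen, so the change has no direct precedent. Compound 4 is therefore expected to show a step of no change at the digits printed from compound 3 to compound 4 (within the scatter), within the scatter. The estimate for compound 4 in this assay is 10000 nM, with a range of 4000 nM to 25000 nM.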

Compound 4, concentration for 50% growth inhibition: 31000 nM
The estimate for compound 4 lay 3.1-fold (0.49 log units) below the measured number; measured number above the stated range.
By their numbers in this assay, from the lowest: compound 1; then compound 3; then compounds 4 and 2 (each within the scatter of the next).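

In this assay, adding one carbon to the acid chain is not a silent change: a 3.1-fold higher number from compound 3 to compound 4 (0.49 log units; beyond the scatter) shows that this place responds to chain length itself, not only to the loss of methoxy. Measured against methoxy, the longer (2-carboxyethyl)amino group gives the larger rise in the number, a 7.9-fold higher number from compound 1 to compound 4 (0.90 log units; beyond the scatter), beside a 2.6-fold higher number from compound 1 to compound 3 (0.41 log units; beyond the scatter) for the shorter (carboxymethyl)amino group. Nothing available explains this shift.

As far as these compounds go, it remains open whether a still longer carboxylic acid chain would continue the trend, and whether the carboxy group matters at all, which a methyl ester or a plain alkyl amine at this place could test.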